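The source may hold more compounds than are shown below. What is called first, only, known or untested is meant among the compounds shown, and "the series" means these compounds.

Measured so far:
- compound 1, `Cc1ccc(N2CCN(C(=O)c3oc(C)nc3-c3ccccc3)CC2)cc1`: in a functional assay on HL-60 cells (Homo sapiens) for inhibition, read by MTT assay, with a stated time of 72 h (on this read-out lower numbers stand for stronger inhibition and higher numbers for weaker inhibition), compound 1 gives > 1000 nM, which is a limit of the assay rather than a number.
- compound 2, `Cc1nc(-c2ccccc2)c(C(=O)N2CCN(c3ccccc3)CC2)o1`: compound 2 gives 39.1 nM.
- compound 3, `Cc1nc(-c2ccccc2)c(C(=O)N2CCN(c3cccc(F)c3)CC2)o1`: compound 3 gives 45 nM.

Compound 3 stands with the highest of the two numbers that were read, but its nearest neighbour compound 2 lies within the scatter of it, shown by a 1.2-fold higher number from compound 2 to compound 3 (0.06 log units; within the scatter); the third value is the limit noted for compound 1 (the limit of > 1000 nM in this assay, at which 1 of the 3 values shown sits).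

The next compound, compound 4, `Cc1nc(-c2ccccc2)c(C(=O)N2CCN(c3cc(Cl)cc(Cl)c3)CC2)o1`, differs from compound 3 in one place: 3,5-dichlorophenyl in place of 3-fluorophenyl on an amine nitrogen in a ring.

Within the data shown here, two measured steps bear on it. The change on the same amine nitrogen from compound 1 to compound 3, an at least 22-fold lower number from compound 1 to compound 3 (1.34 log units; beyond the scatter), shows that the group on that nitrogen can move the number a great deal, while a 1.2-fold higher number from compound 2 to compound 3 (0.06 log units; within the scatter) shows that a single halogen on the ring changed little. Compound 4 carries two chlorines where compound 3 carries one fluorine, so a moderate weakening is expected, a 2.7-fold higher number from compound 3 to compound 4 (0.43 log units; beyond the scatter), though it could fall within the scatter. Compound 4 is therefore estimated at 120 nM, with a range from 40 nM to 600 nM.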

Compound 4, half-maximal inhibitory concentration: 41.8 nM
Beside the measured number, compound 4's estimate is 2.9-fold (0.46 log units) above it; the measured number falls inside the stated range.
By their numbers in this assay, from the lowest: compounds 2, 4 and 3 (each within the scatter of the next). At a limit, above all of these: compound 1.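

In this assay, 3,5-dichlorophenyl on the amine nitrogen in the ring reads the same as the groups already tried there, with a 1.1-fold lower number from compound 3 to compound 4 (0.03 log units; within the scatter) and a 1.1-fold higher number from compound 2 to compound 4 (0.03 log units; within the scatter). The earlier compounds had shown this only for a single fluoro, so the flat stretch now extends to two chloro groups on the same phenyl ring, and 4-methylphenyl alone goes against it, with an at least 23-fold lower number from compound 1 to compound 4 (1.37 log units; beyond the scatter). Compound 1 is a limit and not a number, so that step gives only a bound: the limit of > 1000 nM in this assay, at which 1 of the 4 values shown sits.

What the compounds leave open is whether 4-methylphenyl stands apart for its methyl group or for where that methyl sits on the ring. Also open, from the compounds shown here alone, is how an amine or a carboxylic acid on this phenyl ring would read.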